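The compounds below may be only part of what the source reports. "The series", "measured", "known", "first", "only" and "open" are said of these compounds alone.

In an ADME assay on L02 cells (Homo sapiens) for antiproliferative activity, read by MTT assay, with a stated time of 48 h (on this read-out higher numbers stand for weaker inhibition and lower numbers for stronger inhibition), compound 1 `CCN(CC)CCNC(=O)c1ccc(C(CC)(CC)c2ccc(OCCC(O)(CC)CC)c(C)c2)n1CC` gives 2290 nM. Compound 2 `CCn1c(C(=O)Nc2ccc(OC(F)(F)F)cc2)ccc1C(CC)(CC)c1ccc(OCCC(O)(CC)CC)c(C)c1` gives > 50000 nM, which is a limit of the assay and not a number. Compound 2 therefore stands at the limit of > 50000 nM in this assay, at which 1 of the 2 values shown sits. Compound 3 `CCn1c(C(=O)N(C)CC(=O)O)ccc1C(CC)(CC)c1ccc(OCCC(O)(CC)CC)c(C)c1` keeps the shared core and differs from compound 2 only on the amide: (carboxymethyl)(methyl)amino in place of (4-(trifluoromethoxy)phenyl)amino on a carbonyl carbon. Here (carboxymethyl)(methyl)amino sits in place of (4-(trifluoromethoxy)phenyl)amino on a carbonyl carbon. Among the measured compounds shown here, the one measured step at this place is an at least 21-fold higher number from compound 1 to compound 2 (1.33 log units; beyond the scatter), a large change beyond the scatter. For the measured compounds named here, compound 3 lacks the 2-(diethylamino)ethyl group of compound 1, the only compound here with a measured number, 2290 nM, so no large move toward stronger inhibition is expected. The estimated step is a number no higher from compound 2 to compound 3 (the limit leaves the size open), which means no change beyond the scatter is expected in this assay. For compound 3 the expected value is 50000 nM, with an estimated range of 15000 nM to 150000 nM.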

Compound 3, half-maximal inhibitory concentration: 2150 nM
Beside the measured number, compound 3's estimate is 23-fold (1.37 log units) above it, outside the stated range (below it).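

Replacing the group on the carbonyl carbon gives an at least 23-fold lower number from compound 2 to compound 3 (1.36 log units; beyond the scatter) in this assay, so a compound without the 2-(diethylamino)ethyl group can still give a measured number. Against the earlier compound, (carboxymethyl)(methyl)amino gives a 1.1-fold lower number from compound 1 to compound 3 (0.03 log units; within the scatter), which means that two quite different chains on this carbonyl carbon cannot be told apart in this read-out. Of the three compounds, only compound 2, with its (4-(trifluoromethoxy)phenyl)amino group, stays at a limit of the assay and not a number: the limit of > 50000 nM in this assay, at which 1 of the 3 values shown sits.

On these data alone, it remains open whether the limit of compound 2 goes with its aromatic ring or with the trifluoromethoxy group on that ring. A plain phenylamino group on the same carbonyl carbon would separate those two, and a longer chain ending in a carboxylic acid would show how much the chain length of compound 3 matters.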